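This account rests on a few compounds, and the source may have more. Where it says the series, first, only, none or still open, it means among the compounds named here.

Measured so far in a functional assay (Mus musculus, strain BALB/C) for inhibition, read by MTT assay, with stated times of 24 h and 72 h; on this read-out lower numbers stand for stronger inhibition and higher numbers for weaker inhibition:
Compound 1 `Cc1ccc(C(=O)N/N=C/c2ccccc2O)c(O)c1` gives 1020 nM.
Compound 2 `Cc1ccc(C(=O)N/N=C/c2ccc(Cl)cc2)c(O)c1` gives 12300 nM.

Of these two numbers, compound 2 holds the higher one, so it is the weaker inhibitor of the pair; compound 1 sits at the lower number, and the gap between them is wider than repeated measurements usually scatter. The two compounds share the same core and differ only in the ring that hangs from the hydrazone, so nothing more than that bare comparison can be drawn from them.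

Compound 3 `Cc1ccc(C(=O)N/N=C/c2ccc(N(C)C)cc2)c(O)c1` has not been measured yet. It is compound 2 with one change: dimethylamino in place of chloro on an aromatic carbon. Among the measured compounds shown here, nothing measured here tells how dimethylamino in place of chloro on an aromatic carbon behaves in this assay, so there is no step to lean on. The expectation is therefore modest: a step from compound 2 to compound 3 of a 1.5-fold lower number from compound 2 to compound 3 (0.19 log units; within the scatter), lying within the usual scatter, with the direction left open. Compound 3 is estimated at 8000 nM, between 2000 nM and 30000 nM.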

Compound 3, half-maximal inhibitory concentration: > 100000 nM
Compound 3: no number, only a limit (the forecaster's own chance of this, stated with the estimate: 10%); middle value at least 12-fold (1.09 log units) from the limit.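

In this assay, compound 3 gives > 100000 nM, and this value is a limit of the assay, not a number. Among the compounds shown here, replacing chloro with dimethylamino on this aromatic carbon, para to a large group, gives an at least 8.1-fold higher number from compound 2 to compound 3 (0.91 log units; beyond the scatter), so what sits at this position matters, and this change moves toward weaker inhibition, which the earlier compounds could not show because they offered no step that changed one place only. Going by these compounds, the true size of the loss stays unknown, since the reading stops at the limit: the limit of > 100000 nM in this assay, at which 1 of the 3 values shown sits.

The compounds shown leave open whether this loss belongs to dimethylamino in particular or would follow from many other replacements of chloro on this carbon, as a single step cannot separate the two. A methoxy group, a primary amine or a carboxylic acid at the same position would show whether inhibition survives with other groups there, and whether a measurable number can be recovered at all in place of a limit.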